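Carbamate in Place of Pyrimidine on the Ring Nitrogen

This account rests on a few compounds, and the source may have more. Where it says the series, first, only, none or still open, it means among the compounds named here.

Measured compounds:
compound 1 `O=C(Nc1ccc(Cl)cc1)C1(c2ccc3c(n2)CCN3c2ccccn2)CCC1` with 2.3 nM
compound 2 `O=C(Nc1ccc(Cl)cc1)C1(c2ccc3c(c2)CCN3c2ccccn2)CCC1` with 1.6 nM
compound 3 `O=C(NC1(c2ccc3c(n2)CCN3c2ccnc(C(F)(F)F)n2)CCC1)c1ccc(Cl)cc1` with 93 nM

In an assay on HeLa cells for inhibition of Indoleamine 2,3-dioxygenase 1 (Homo sapiens) (a higher number here means a weaker inhibitor, a lower number a stronger inhibitor), compound 3 stands at the high end of the three numbers. Its nearest neighbour is compound 1, whose number is lower by a step that lies beyond the scatter, and compound 2 lies further still below it, also beyond the scatter. Compound 3 is therefore the weakest inhibitor of the three as measured.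

Compound 4 `COCCOC(=O)N1CCc2nc(C3(NC(=O)c4ccc(Cl)cc4)CCC3)ccc21` has not yet been measured. It differs from compound 3 in one place: (2-methoxyethoxy)carbonyl in place of 2-(trifluoromethyl)pyrimidin-4-yl on a nitrogen on an aromatic ring in a ring. Within the data shown here, nothing among the measured compounds shows what such an exchange does; compounds 1 and 2 carry a different group on that nitrogen and also a reversed amide, so they cannot stand in for it.

The expectation rests only on compound 3 and its value 93 nM. A modest step toward a weaker inhibitor is expected, with a wide spread, since the group that enters has no ring where the group that leaves had one. For compound 4 the estimated number in this assay is 200 nM, within a range from 40 nM to 1500 nM. This corresponds to an expected step of a 2.2-fold higher number from compound 3 to compound 4 (0.33 log units; beyond the scatter).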

Compound 4, half-maximal inhibitory concentration: 6.9 nM
For compound 4 the middle estimate is 29-fold (1.46 log units) above the measured one, and the stated range ends above it.
By their numbers in this assay, from the lowest: compounds 2 and 1 (each within the scatter of the next); then compound 4; then compound 3.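

In this assay, putting (2-methoxyethoxy)carbonyl in place of 2-(trifluoromethyl)pyrimidin-4-yl on this nitrogen gives a 13-fold lower number from compound 3 to compound 4 (1.13 log units; beyond the scatter), a large step that lies beyond the scatter. The pair shows that, on this nitrogen of the five-membered non-aromatic ring, an aromatic ring is not needed for a low number with this amide and the rest of the core unchanged: the entering group has no ring and no fluorine, and it brings a double bond outside aromatic rings and oxygen in a chain. No measurement at hand says why the number falls.

A single exchange changes all of these features at once, so the compounds shown leave open how much of the step belongs to the carbonyl, how much to the methoxyethyl chain and how much to the loss of the 2-(trifluoromethyl)pyrimidin-4-yl group; a plain methyl carbamate, an acetyl group or a pyrimidin-4-yl ring without trifluoromethyl would begin to separate them. On these data alone, it also remains open whether the same exchange would give a step of similar size on a compound with the reversed amide of compounds 1 and 2.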